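The source may report more compounds than this note shows. Statements on the series, on what has been measured and on what is new or still open speak of the compounds shown alone.

Measured in a functional assay on the whole organism for agonist activity, with Mus musculus as the target; a lower number here means that less compound is needed, a higher number that more compound is needed for the effect:
- compound 1 `CC(=O)N(C)C(C)C#CCn1ccnc1`: 3 mg/kg
- compound 2 `CC(=O)N(C)C(C)C#CCn1cncc1C`: > 100 mg/kg (a limit)
- compound 3 `CC(=O)N(C)CC#CCn1ccnc1`: 1.4 mg/kg

Among the two actual numbers in this assay, compound 1 is the higher at 3 mg/kg, and its nearest neighbour is compound 3 at 1.4 mg/kg. Compound 2 stands at > 100 mg/kg, which is a limit of the assay and not a number.

Compound 4 `COC(=O)N(C)C(C)C#CCn1ccnc1` has not yet been measured. It differs from compound 1 by methoxy in place of methyl on a carbonyl carbon, or acetyl to methoxycarbonyl.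

Neither measured step changes this carbonyl group, so both bear on it only indirectly. One is large, an at least 33-fold higher number from compound 1 to compound 2 (1.52 log units; beyond the scatter), with methyl in place of hydrogen on an aromatic carbon. The other is modest, a 2.1-fold lower number from compound 1 to compound 3 (0.33 log units; beyond the scatter), at a saturated chain carbon. Compound 2 shows with an at least 33-fold higher number from compound 1 to compound 2 (1.52 log units; beyond the scatter) that one small addition can cost a great deal here, so a modest rise is expected, with a wide margin and some risk of a much larger one.

The expected step is a 2.0-fold higher number from compound 1 to compound 4 (0.30 log units; within the scatter). For compound 4 the estimated value is 6 mg/kg, with an expected range of 1.5 mg/kg to 40 mg/kg.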

Compound 4, dose for half-maximal effect: 8 mg/kg
For compound 4 the middle estimate is 1.3-fold (0.12 log units) below the measured one, within the range that was stated.
By their numbers in this assay, from the lowest: compound 3; then compound 1; then compound 4. At a limit, above all of these: compound 2.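

In this assay, changing acetyl to methoxycarbonyl gives a 2.7-fold higher number from compound 1 to compound 4 (0.43 log units; beyond the scatter) as the only step shown at this carbonyl carbon, so methoxy in place of methyl carries a modest cost here and compound 4 keeps an actual number. The addition on the aromatic carbon ends differently: compound 2 stands at > 100 mg/kg in this assay, and that value is a limit of the assay and not a number. Nothing measured here accounts for the step to compound 4, so the data give no reason for it.

With only methyl and methoxy shown on this carbonyl carbon, the compounds leave open whether the rise follows the added oxygen or simply the larger group, and an ethyl group, an ethoxy group or a dimethylamino group at this place could separate those readings. On these data alone, it also remains open whether methoxycarbonyl would cost the same on the core of compound 3, which lacks the methyl on the saturated chain carbon, as it does on the core of compound 1.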